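Compound 2 to compound 4: methyl gives way to hydrogen

A few compounds are considered here, and "the series" means these few. Any claim that something is new, unique, unknown or untested is made for them only; others in the source may bear on it.

In a functional assay on Caco-2 cells (Homo sapiens) for cytotoxicity, read by MTT assay, with stated times of 6 h and 48 h (a lower number here means a stronger inhibitor, a higher number a weaker inhibitor), three compounds have been measured:
Compound 1 (`Cn1c(-c2cc(-c3ccccc3)no2)cc(Br)c1Br`): 16600 nM
Compound 2 (`Cn1c(-c2cc(-c3ccccc3O)no2)cc(Br)c1Br`): >= 100000 nM (a limit)
Compound 3 (`Brc1cc(-c2cc(-c3ccc[nH]3)no2)[nH]c1Br`): >= 100000 nM (a limit)

Compound 2 gives no number and sits at the limit of >= 100000 nM in this assay, at which 2 of the 3 values shown sit, in the data so far. Compound 4 (`Oc1ccccc1-c1cc(-c2cc(Br)c(Br)[nH]2)on1`) differs from it by hydrogen in place of methyl on an aromatic nitrogen. Among the measured compounds shown here, no measured step makes this change. For the measured compounds named here, the one measured step, an at least 6.0-fold higher number from compound 1 to compound 2 (0.77 log units; beyond the scatter), is a different change and bears on it only by placing compound 2 at the limit. Compound 3 also carries hydrogen on an aromatic nitrogen and gives only a limit (>= 100000 nM). No step beyond the scatter is therefore expected in this assay, and the estimate is a number no higher from compound 2 to compound 4 (the limit leaves the size open) as an expected step. Compound 4 is expected at about 100000 nM, within an estimated range of 40000 nM to 250000 nM, and may well return only a limit.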

Compound 4, half-maximal inhibitory concentration: >= 100000 nM
Compound 4 ended at the assay's limit; the forecaster's own chance of this, stated with the estimate: 70%; the middle value sits exactly at the limit.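

In this assay compound 4 gives >= 100000 nM, which is a limit. Compound 2 also stands at a limit, so no step can be read between compound 2 and compound 4. The compounds shown leave open whether hydrogen in place of methyl on an aromatic nitrogen changes the value at all.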